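The source may report more compounds than this note shows. Statements on the series, on what has been measured and on what is new or still open speak of the compounds shown alone.

Compound 2 `O=C(CCCOc1ccc(OCc2ccc3ccccc3n2)cc1)NS(=O)(=O)c1ccccc1`: 19 nM
Compound 1 `c1ccc2nc(COc3ccc(OCCCc4nnn[nH]4)cc3)ccc2c1`: 250 nM

Of the compounds shown here, two have been measured in a functional assay (Cavia porcellus) for inhibition of cysteinyl leukotriene receptor (Homo sapiens); a higher number here means a weaker inhibitor, a lower number a stronger inhibitor. Compound 2 gives 19 nM, and compound 1 gives 250 nM. Among the compounds with values here, compound 2 therefore stands lowest of the two numbers, and its only neighbour, compound 1, lies beyond the scatter above it. The unmeasured compound 3 `CCOC(=O)CCCOc1ccc(OCc2ccc3ccccc3n2)cc1` keeps the shared core of compound 2 and differs from it in one place: ethoxy in place of (phenylsulfonyl)amino on a carbonyl carbon. Within the data shown here, no measured pair shows this exchange, so nothing in the data fixes its size. The account nevertheless expects compound 3 to be a weaker inhibitor than compound 2 in this assay, with an estimated step of a 21-fold higher number from compound 2 to compound 3 (1.32 log units; beyond the scatter), a loss that would go beyond the usual scatter. Compound 3 is estimated at 400 nM, within a range from 80 nM to 3000 nM.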

Compound 3, half-maximal inhibitory concentration: 2000 nM
Beside the measured number, compound 3's estimate is 5.0-fold (0.70 log units) below it, and the stated range covers the measured number.
By their numbers in this assay, from the lowest: compound 2; then compound 1; then compound 3.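

Putting ethoxy in place of (phenylsulfonyl)amino on a carbonyl carbon gives a 110-fold higher number from compound 2 to compound 3 (2.02 log units; beyond the scatter) in this assay and so shows that the group at this place accounts for a large part of the inhibition seen with the shared core. Ethoxycarbonyl in place of 1H-tetrazol-5-yl on the saturated chain carbon gives an 8.0-fold higher number from compound 1 to compound 3 (0.90 log units; beyond the scatter) as a smaller but still clear loss, which leaves compound 3 with the highest number of the three. Nothing measured here explains either step.

From the compounds shown here alone, it remains open whether a carboxylic acid on the same chain would stand closer to compound 2 or to compound 3. Going by these compounds, it is also open whether a methyl group in place of the phenyl ring on the sulfonyl, or a longer chain, would keep the number of compound 2.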